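The compounds below may be only part of what the source reports. "The series", "measured", "known", "first", "only" and "open" are said of these compounds alone.

Measured so far in a functional assay on MGC-803 cells (Homo sapiens) for antiproliferative activity, read by MTT assay, with a stated time of 72 h; on this read-out higher numbers stand for weaker inhibition and lower numbers for stronger inhibition: compound 1 `CCCSc1nc(N/N=C(\C)c2ccccc2O)c2nnn(Cc3ccccc3Cl)c2n1` gives 35000 nM; compound 2 `CCCSc1nc(N/N=C(\C)c2ccccc2O)c2nnn(Cc3ccc(O)cc3)c2n1` gives 7680 nM; compound 3 `CCCSc1nc(N/N=C(\C)c2ccccc2O)c2nnn(Cc3cccc(Cl)c3)c2n1` gives 6500 nM.

Compound 3 carries the lowest number of the three, but compound 2 sits within the scatter of it; only compound 1 stands clearly apart, as a 5.4-fold lower number from compound 1 to compound 3 (0.73 log units; beyond the scatter) and a 4.6-fold lower number from compound 1 to compound 2 (0.66 log units; beyond the scatter) show. Compound 4 `CCCSc1nc(N/N=C(\C)c2ccccc2O)c2nnn(Cc3ccc(Br)cc3)c2n1` differs from compound 3 by 4-bromophenyl in place of 3-chlorophenyl on a saturated chain carbon bound to an aromatic nitrogen. For the measured compounds named here, the step that bears most directly is a 1.2-fold lower number from compound 2 to compound 3 (0.07 log units; within the scatter), where a 4-hydroxyphenyl and a 3-chlorophenyl gave numbers within the scatter of each other; no measured step compares two halogens. A step no larger than the scatter is therefore expected in this assay, estimated as a 1.1-fold higher number from compound 3 to compound 4 (0.03 log units; within the scatter). Compound 4 is expected at 7000 nM, within 3000 nM to 17000 nM.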

Compound 4, half-maximal inhibitory concentration: 11300 nM
For compound 4 the middle estimate is 1.6-fold (0.21 log units) below the measured one; low and high end bracket the measured number.
By their numbers in this assay, from the lowest: compounds 3, 2 and 4 (each within the scatter of the next); then compound 1.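

In this assay, a bromine-bearing group at this position joins the 3-chlorophenyl and 4-hydroxyphenyl groups within the scatter (with a 1.7-fold higher number from compound 3 to compound 4 (0.24 log units; within the scatter) and a 1.5-fold higher number from compound 2 to compound 4 (0.17 log units; within the scatter)). The 2-chlorophenyl group of compound 1 remains the only one clearly apart, now also against the 4-bromophenyl group (a 3.1-fold lower number from compound 1 to compound 4 (0.49 log units; beyond the scatter)). Nothing available gives a reason for this separation.

The change from 3-chlorophenyl to 4-bromophenyl alters both halogen and ring position, and these two contributions remain unseparated. Also open, going by these compounds, is whether an amine or a carboxylic acid on the phenyl ring would move the number beyond the scatter.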